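The source may hold more compounds than are shown below. What is called first, only, known or untested is meant among the compounds shown, and "the series" means these compounds.

Measured so far:
- compound 1 `Nc1sc2c(c1C(=O)O)CCN(Cc1ccccc1)C2`: 8000 nM
- compound 2 `CC(C)(C)OC(=O)N1CCc2c(sc(N)c2C(=O)O)C1`: 12100 nM

Both compounds were tested in an in vitro assay on CHOk1 cells with adenosine receptor A1 (Homo sapiens) as the target; a lower number here means that less compound is needed, a higher number that more compound is needed for the effect. Compound 1 gives 8000 nM and compound 2 gives 12100 nM; the two numbers lie within the scatter of each other, so neither compound can be set apart from the other on these data. Compound 1 is simply the one of the two with the numerically smaller reading, and both readings sit in the weak range.

The next compound, compound 3 `Nc1sc2c(c1C(=O)NCc1ccccc1)CCN(Cc1ccccc1)C2`, has not yet been measured. It differs from compound 1 in one place: benzylamino in place of hydroxy on a carbonyl carbon. The carboxylic acid of compound 1 thus becomes a benzylamide.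

For the measured compounds named here, no step between measured compounds is available for this series, so the size of the change from an acid to an amide here cannot be read off from anything measured. Since a single donor is kept and a second benzyl group is brought in, the expectation is a moderate move toward a lower number rather than none at all, with the step from compound 1 to compound 3 estimated at a 3.2-fold lower number from compound 1 to compound 3 (0.51 log units; beyond the scatter). For compound 3 the expected value in this assay is 2500 nM, with a range from 400 nM to 15000 nM.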

Compound 3, half-maximal effective concentration: 13100 nM
For compound 3 the middle estimate is 5.2-fold (0.72 log units) below the measured one, and the stated range covers the measured number.
By their numbers in this assay, from the lowest: compounds 1, 2 and 3 (each within the scatter of the next).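

Putting benzylamino in place of hydroxy on the carbonyl carbon gives, in this assay, a 1.6-fold higher number from compound 1 to compound 3 (0.21 log units; within the scatter), so this change cannot be told apart from no change at all. For this pair, then, the carboxylic acid is not needed for a reading in the weak range, and the benzylamide, with its added aromatic ring, leaves the number where the scatter cannot separate it from that of the acid. Nothing available on these compounds speaks to why the reading holds across this change.

Open, on these data alone, is whether any other group on this carbonyl carbon would give a step beyond the scatter, for instance methylamino, a longer phenethylamino chain or a methoxy group forming an ester. Also open, as far as these compounds go, is how much the amino group of the shared core and the benzyl group common to compound 1 and compound 3 contribute, since neither is varied in a single step here.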